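Ethoxycarbonyl in place of methyl on the shared core

The source may report more compounds than this note shows. Statements on the series, on what has been measured and on what is new or still open speak of the compounds shown alone.

Measured so far:
compound 1, `Cc1ccc2nc(NC(=O)CNC(=O)c3nn(-c4ccccc4)c(=O)c4ccccc34)sc2c1`, gives 35 nM in an assay on L cells for inhibition of Protein-serine O-palmitoleoyltransferase porcupine (Mus musculus), read by reporter gene assay, with a stated time of 24 h; a higher number here means that more compound is needed for the effect, a lower number that less compound is needed
compound 2, `COc1ccc(-n2nc(C(=O)NCC(=O)Nc3nc4ccc(C)cc4s3)c3ccccc3c2=O)cc1`, gives 25 nM in this assay

For the measured compounds named here, compound 1 holds the higher of the two numbers so far; its nearest neighbour is compound 2, and the step of a 1.4-fold lower number from compound 1 to compound 2 (0.15 log units; within the scatter) lies within the scatter, so the two are not separable.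

Compound 3, `CCOC(=O)c1ccc2nc(NC(=O)CNC(=O)c3nn(-c4ccccc4)c(=O)c4ccccc34)sc2c1`, differs from compound 1 by ethoxycarbonyl in place of methyl on an aromatic carbon. Going by the values given here, neither measured step touches this position or this kind of exchange; the one step available, a 1.4-fold lower number from compound 1 to compound 2 (0.15 log units; within the scatter), concerns a substituent elsewhere and shows no movement beyond the scatter. Among the compounds with values here, there is therefore no direct precedent, and the expectation rests on the size of the exchange alone. A modest rise in the number is expected, a 1.7-fold higher number from compound 1 to compound 3 (0.23 log units; within the scatter), but with wide uncertainty. For compound 3 the estimate in this assay is 60 nM, with a range from 20 nM to 200 nM.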

Compound 3, half-maximal effective concentration: > 25000 nM
Compound 3 ended at the assay's limit; the forecaster's own chance of this, stated with the estimate: 5%; middle value at least 410-fold (2.61 log units) from the limit.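

The aromatic carbon that carries methyl on the shared core proves sensitive to exchange: ethoxycarbonyl in place of methyl gives an at least 710-fold higher number from compound 1 to compound 3 (2.85 log units; beyond the scatter). For the compounds shown here, the only earlier step, a 1.4-fold lower number from compound 1 to compound 2 (0.15 log units; within the scatter), concerned another place and stayed within the scatter, so it gave no sign that any part of the series could respond this sharply. For compound 3 the reading in this assay is a limit of the assay and not a number: the limit of > 25000 nM in this assay, at which 1 of the 3 values shown sits.

Open, on these data alone, is whether the loss follows from the larger count of heavy atoms in ethoxycarbonyl or from its hydrogen-bond acceptors; an ethyl group, a carboxylic acid or a primary amide on the same carbon would help separate these. Also open is how far the loss extends, since the compounds shown hold only methyl and ethoxycarbonyl at this place.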